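Series notes: moving from nitro back to chloro

The source may report more compounds than this note shows. Statements on the series, on what has been measured and on what is new or still open speak of the compounds shown alone.

Measured so far:
Compound 1 `O=C1/C(=C\c2ccccc2Cl)c2ccccc2N1c1c(Cl)cccc1Cl`: 5 ug/mL
Compound 2 `O=C1/C(=C\c2ccccc2[N+](=O)[O-])c2ccccc2N1c1c(Cl)cccc1Cl`: 1 ug/mL

In a functional assay on KB cells (Homo sapiens) for cytotoxicity, read by MTT assay, with a stated time of 72 h (on this read-out lower numbers stand for an effect already at smaller amounts and higher numbers for an effect only at larger amounts of compound), compound 1 gives 5 ug/mL and compound 2 gives 1 ug/mL. Among the measured compounds shown here, compound 2 therefore holds the lowest number of the two, and the one measured step, a 5.0-fold lower number from compound 1 to compound 2 (0.70 log units; beyond the scatter), separates it from compound 1.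

Compound 3 `O=C1/C(=C\c2cccc(Cl)c2)c2ccccc2N1c1c(Cl)cccc1Cl` is not yet measured in this assay. It differs from compound 2 by 3-chlorophenyl in place of 2-nitrophenyl on a double-bonded chain carbon bound to a double-bonded ring carbon. The change undoes the nitro-for-chloro exchange of the measured step, though the chloro now enters as part of 3-chlorophenyl rather than where it stood in compound 1, so the step between compound 1 and compound 2 bears on it only as an approximate mirror image. That step was a 5.0-fold lower number from compound 1 to compound 2 (0.70 log units; beyond the scatter); reversing the exchange is expected to give a step of similar size in the opposite direction, so compound 3 is expected to return to the neighbourhood of compound 1 rather than stay with compound 2. The expected step is a 4.0-fold higher number from compound 2 to compound 3 (0.60 log units; beyond the scatter), with wide uncertainty since the chloro position is not matched by any measured pair. Compound 3 is expected at 4 ug/mL in this assay, within a range of 1.5 ug/mL to 12 ug/mL.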

Compound 3, concentration for half-maximal effect: 2 ug/mL
Compound 3: the middle estimate sits 2.0-fold (0.30 log units) above what was measured; low and high end bracket the measured number.
By their numbers in this assay, from the lowest: compounds 2 and 3 (each within the scatter of the next); then compound 1.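

In this assay, the step of a 2.0-fold higher number from compound 2 to compound 3 (0.30 log units; within the scatter) leaves 3-chlorophenyl and 2-nitrophenyl inseparable on this double-bonded chain carbon, so a nitro group is not needed for a number in this range, which the earlier pair could not show. Among the compounds shown here, the other step, a 2.5-fold lower number from compound 1 to compound 3 (0.40 log units; beyond the scatter) with 3-chlorophenyl in place of 2-chlorophenyl, is the first comparison in which the same substituent differs only in where it sits on this aromatic ring, and that difference alone lies beyond the scatter. No measurement at hand accounts for either step.

The compounds shown leave open whether a nitro group would give a comparable shift if carried in the arrangement of 3-chlorophenyl, as chloro is the only substituent seen here in two arrangements. Also open, on these data alone, is how an amine, a methoxy group or a carboxylic acid on this aromatic ring would read in this assay and whether any such group would separate from compound 2 and compound 3 beyond the scatter.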